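The source may hold more compounds than are shown below. What is called first, only, known or untested is meant among the compounds shown, and "the series" means these compounds.

Compound 1 `CC(=O)N1CCC(c2ccc3c(c2)oc(=O)n3C(=O)NCCCCc2ccccc2)CC1` and compound 2 `CC(C)CN1CCC(c2ccc3c(c2)oc(=O)n3C(=O)NCCCCc2ccccc2)CC1` share one core and differ by isobutyl in place of acetyl on an amine nitrogen in a ring. In a physicochemical assay for solubility, read by HPLC, in phosphate buffer, measured as kinetic solubility, with a stated time of 1 h, at pH 7.4, tested at 250 uM (on this read-out higher numbers stand for higher solubility and lower numbers for lower solubility), compound 1 gives only a limit of the assay, < 1000 nM. In this assay compound 2 likewise gives only a limit of the assay, < 1000 nM. The step that the two limits leave unreadable from compound 1 to compound 2 therefore cannot be read, and the limit of < 1000 nM in this assay, at which 2 of the 2 values shown sit, is all the measured evidence there is. Compound 3 `CN1CCC(c2ccc3c(c2)oc(=O)n3C(=O)NCCCCc2ccccc2)CC1` differs from compound 2 by hydrogen in place of isopropyl on a saturated chain carbon bound to an amine nitrogen in a ring. Going by the values given here, no measured step covers this change, and the two measured values are both limits; they give no size or direction for it. Compound 3 is therefore expected to stand near the same limit, with the step that the limit leaves unreadable from compound 2 to compound 3 expected to be small. For compound 3 the estimate in this assay is 600 nM, with a range from 100 nM to 3000 nM.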

Compound 3, solubility: 120000 nM
For compound 3 the middle estimate is 200-fold (2.30 log units) below the measured one; measured number outside the range, above it.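

The substituent on the amine nitrogen in a ring, which the first pair left unreadable, proves decisive for the read-out in this assay: replacing isobutyl with methyl gives an at least 120-fold higher number from compound 2 to compound 3 (2.07 log units; beyond the scatter), and replacing acetyl with methyl gives an at least 120-fold higher number from compound 1 to compound 3 (2.07 log units; beyond the scatter). Both sizes are minimum values, since each step starts from a limit of the assay, so the true gaps may be larger. Only compound 3 leaves the floor shared by the other two compounds, and the remaining record is: the limit of < 1000 nM in this assay, at which 2 of the 3 values shown sit.

As far as these compounds go, the step between compound 1 and compound 2 still cannot be read, so the order of acetyl and isobutyl stays unknown. From the compounds shown here alone, whether the high reading is specific to methyl, or would also appear with a plain hydrogen on that nitrogen, an ethyl or a longer chain, remains open.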